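A few compounds are considered here, and "the series" means these few. Any claim that something is new, unique, unknown or untested is made for them only; others in the source may bear on it.

Measured in a functional assay on MCF7 cells (Homo sapiens) for cytotoxicity, read by MTT assay, with a stated time of 24 h, tested at 10 uM; on this read-out lower numbers stand for a stronger effect and higher numbers for a weaker effect at the one concentration tested:

compound 1, `Cc1nc2c(Br)c(Br)c(Br)c(Br)c2n1CCCCC#N`: 109%
compound 2, `Cc1nc2c(Br)c(Br)c(Br)c(Br)c2n1CCC#N`: 85%
compound 3, `Cc1nc2c(Br)c(Br)c(Br)c(Br)c2n1CCCC#N`: 65%

Compound 1 stands highest of the three numbers. Its nearest neighbour is compound 2, reached by a number 24 percentage points lower from compound 1 to compound 2 (beyond the scatter); the furthest is compound 3, reached by a number 44 percentage points lower from compound 1 to compound 3 (beyond the scatter). Compound 2 and compound 3 are separated by a number 20 percentage points lower from compound 2 to compound 3 (beyond the scatter). All three measured steps change the chain that carries the nitrile, and each of them lies beyond the scatter.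

Compound 4, `N#CCCCCn1cnc2c(Br)c(Br)c(Br)c(Br)c21`, differs from compound 1 in another place: hydrogen in place of methyl on an aromatic carbon. For the measured compounds named here, none of the measured steps touches this aromatic carbon between the two ring nitrogen atoms, so no step bears directly on the change; the measured steps only show how far this series moves when the chain is altered, by modest to large amounts. With nothing to point to a direction, the account expects no step beyond the scatter in this assay from compound 1 to compound 4, and the expected step is a number 9 percentage points lower from compound 1 to compound 4 (within the scatter). Compound 4 is therefore estimated to give 100% in this assay, within a range from 80% to 120%.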

Compound 4, a percentage reported as activity, at one concentration (the size of the read-out at that concentration, not a potency): 102%
For compound 4 the middle estimate is 2 percentage points below the measured one; low and high end bracket the measured number.
By their numbers in this assay, from the lowest: compound 3; then compound 2; then compounds 4 and 1 (each within the scatter of the next).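

In this assay, hydrogen in place of methyl on the aromatic carbon between two ring nitrogen atoms gives a number 7 percentage points lower from compound 1 to compound 4 (within the scatter), the only step shown that leaves the chain untouched. This sets the position apart from the chain that carries the nitrile, where changes give steps such as a number 44 percentage points lower from compound 1 to compound 3 (beyond the scatter): with the 4-cyanobutyl group kept, this methyl can be exchanged for hydrogen without a change beyond the scatter, and compound 4 at 102% reads the same as compound 1 at 109% within that scatter. No evidence on hand accounts for this outcome.

As far as these compounds go, compound 1 and compound 4 both carry the 4-cyanobutyl group, so it remains open whether the same exchange would stay within the scatter on the shorter chains of compound 2 and compound 3, whose numbers lie lower in this read-out. It also remains open how the read-out would respond to an amine, a phenyl ring or a longer alkyl chain on this aromatic carbon, since methyl and hydrogen are the only two groups shown there.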